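This account rests on a few compounds, and the source may have more. Where it says the series, first, only, none or still open, it means among the compounds named here.

In a functional assay on MCF7 cells (Homo sapiens) for cytotoxicity, read by MTT assay, with a stated time of 48 h, tested at 100 uM (on this read-out higher numbers stand for more inhibition of growth at the one concentration tested and lower numbers for less inhibition of growth), compound 3 (`C#CCNC(=O)Nc1cccc(CNCc2ccc(OC(F)(F)F)cc2)c1`) gives 30%, level with compound 2 (`C#CCNC(=O)Nc1cccc(CNCc2ccc(C)cc2)c1`), which gives 30%. Compound 1 (`C#CCNC(=O)Nc1cccc(CCl)c1`) gives 85.2%, a gap beyond the scatter from both. Next comes compound 4 (`C#CCNC(=O)Nc1cccc(CNCc2ccc(OC)cc2)c1`), with methyl in place of trifluoromethyl on an oxygen on an aromatic ring, or trifluoromethoxy to methoxy. Among the compounds with values here, one measured step bears on this: no change at the digits printed from compound 2 to compound 3 (within the scatter), for trifluoromethoxy in place of methyl on an aromatic carbon. That step is close in kind but not the same change. No step beyond the scatter is therefore expected in this assay. The estimated step is no change at the digits printed from compound 3 to compound 4 (within the scatter). For compound 4 the estimated value is 30%, with an expected range of 15% to 45%.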

Compound 4, percent growth inhibition at one concentration: 30%
Compound 4: middle estimate and measured number agree at the digits printed; low and high end bracket the measured number.
By their numbers in this assay, from the lowest: compounds 2, 3 and 4 (each within the scatter of the next); then compound 1.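

In this assay, changing the group on the oxygen on an aromatic ring gives no change at the digits printed from compound 3 to compound 4 (within the scatter), for methyl in place of trifluoromethyl. Methoxy and methyl on the aromatic carbon also read alike, with no change at the digits printed from compound 2 to compound 4 (within the scatter), a comparison the earlier compounds could not give. Methyl, trifluoromethoxy and methoxy therefore sit at one level at this position, and this read-out does not separate them.

No measurement at hand explains this flat result. Still open, going by these compounds, is whether an amine or a carboxylic acid at this position would move the number beyond the scatter.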